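The source may report more compounds than this note shows. Statements on the series, on what has been measured and on what is new or still open speak of the compounds shown alone.

Measured so far:
- Compound 1 `CCOC(=O)CCCn1nc(-c2cccnc2)c2ccccc2c1=O`: 10000 nM
- Compound 2 `COC(=O)c1ccc(Cn2nc(-c3cccnc3)c3ccccc3c2=O)cc1`: 5890 nM
- Compound 3 `O=c1c2ccccc2c(-c2cccnc2)nn1CCSc1nccs1`: 10500 nM

In a functional assay (trachea) with Cavia porcellus as the target (on this read-out lower numbers stand for stronger inhibition and higher numbers for weaker inhibition), compound 3 gives 10500 nM, which lies within the scatter of both other compounds, so the three form one level group with no resolved order.

The next compound is compound 4 `O=C(O)c1ccc(Cn2nc(-c3cccnc3)c3ccccc3c2=O)cc1`. It carries 4-carboxyphenyl in place of ((1,3-thiazol-2-yl)sulfanyl)methyl on a saturated chain carbon bound to an aromatic nitrogen.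

Within the data shown here, only one measured step bears directly on this chain: a 1.1-fold higher number from compound 1 to compound 3 (0.02 log units; within the scatter). That replacement leaves the number unresolved from its starting point, although it is a single example. Compound 2, at 5890 nM, is the closest measured structure, with a methyl ester where compound 4 has the free acid. Among the measured compounds shown here, no measured step shows what going from an ester to its acid does here, so this remains the main uncertainty and the range is kept wide.

No shift beyond the scatter is therefore expected in this assay, and the expected step is a 1.1-fold lower number from compound 3 to compound 4 (0.02 log units; within the scatter).

For compound 4 the estimated value is 10000 nM, with an expected range from 3000 nM to 35000 nM.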

Compound 4, half-maximal inhibitory concentration: 17000 nM
Estimate against measurement, compound 4: 1.7-fold (0.23 log units) below; measured number inside the range.
By their numbers in this assay, from the lowest: compounds 2, 1, 3 and 4 (each within the scatter of the next, the first and the last beyond it).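

In this assay, among these compounds, the change of hydrogen in place of methyl on an oxygen next to a carbonyl group gives the first measured step from an ester to its acid (a 2.9-fold higher number from compound 2 to compound 4 (0.46 log units; beyond the scatter)), and it is the only step so far that is resolved, though modest. The other two comparisons stay unresolved (a 1.6-fold higher number from compound 3 to compound 4 (0.21 log units; within the scatter) and a 1.7-fold higher number from compound 1 to compound 4 (0.23 log units; within the scatter)), so at this place 4-carboxyphenyl separates from the methyl ester of compound 2 but not from ((1,3-thiazol-2-yl)sulfanyl)methyl or from 2-(ethoxycarbonyl)ethyl. No supporting data bear on why the free acid reads weaker than its methyl ester.

On these data alone, whether this modest loss belongs to the free acid itself or holds only for this one pair remains open, since a single pair carries it. A primary amide or a hydroxymethyl group in place of the methyl ester of compound 2 would show how far the read-out follows that end of the substituent, and an amine there would test the same question from another side.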